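This account rests on a few compounds, and the source may have more. Where it says the series, first, only, none or still open, it means among the compounds named here.

Compound 1 `CCc1ccc(-c2nc3c(c(C)nn3-c3ccccc3)c(-c3ccccc3C#N)c2C#N)cc1`: > 20000 nM
Compound 2 `CCc1ccc(-c2nc3c(c(C)nn3-c3ccccc3)c(-c3ccc(O)cc3)c2C#N)cc1`: > 20000 nM

In an ADME assay on BJ cells (Homo sapiens) for cytotoxicity, with a stated time of 72 h (on this read-out lower numbers stand for an effect already at smaller amounts and higher numbers for an effect only at larger amounts of compound), compound 1 gives > 20000 nM, which is a limit of the assay rather than a measured number. Compound 2 likewise gives only a limit, > 20000 nM. Within the data shown here, the single step between measured compounds, a step that the two limits leave unreadable from compound 1 to compound 2, cannot be read, since (the limit of > 20000 nM in this assay, at which 2 of the 2 values shown sit). Compound 3 `C#Cc1ccccc1-c1c(C#N)c(-c2ccc(CC)cc2)nc2c1c(C)nn2-c1ccccc1` has not yet been measured. It differs from compound 1 as ethynyl in place of cyano on an aromatic carbon. No measured step bears on that change; the one step shown stays unreadable, and nothing in the data points to a direction in which the value should move, or to any movement beyond the scatter. Compound 3 is therefore expected to give about 30000 nM in this assay, with a range from 10000 nM to 100000 nM, most likely reported once more as a limit. For compound 3 this means an expected step that the limit leaves unreadable from compound 1 to compound 3.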

Compound 3, half-maximal effective concentration: > 20000 nM
Compound 3 ended at the assay's limit (the forecaster's own chance of this, stated with the estimate: 85%); the middle value lies beyond the limit too.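

Among these compounds, compound 1, compound 2 and compound 3 all end at a limit in this assay, so no step among them can be read: the limit of > 20000 nM in this assay, at which 3 of the 3 values shown sit.

The compounds shown leave open at what concentration any of the three acts on these cells, and whether ethynyl in place of cyano changes that concentration.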